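The compounds below may be only part of what the source reports. "The series", "measured", "known", "first", "only" and "open" are said of these compounds alone.

Of the compounds shown here, three have been measured in an assay on brain for binding affinity to Neuronal acetylcholine receptor; alpha4/beta2 (Rattus norvegicus), read by radioligand binding; on this read-out higher numbers stand for weaker inhibition and lower numbers for stronger inhibition. Compound 1 `c1ccc(-c2cncc(OC[C@@H]3CCN3)c2)cc1` gives 0.046 nM in this assay. Compound 2 `Clc1cc(OC[C@@H]2CCN2)cnc1Cl` gives 0.023 nM. Compound 3 `Clc1ncc(OC[C@@H]2CCN2)cc1Br` gives 0.015 nM, the lowest of the three numbers, although its gap to compound 2 lies within the usual scatter and only its gap to compound 1 lies beyond it.

Compound 4 `Clc1ncc(OC[C@@H]2CCN2)cc1-c1ccccc1` has not yet been measured in this assay. It differs from compound 3 by phenyl in place of bromo on an aromatic carbon. Among the measured compounds shown here, the only single-place step among the measured compounds is a 1.5-fold lower number from compound 2 to compound 3 (0.19 log units; within the scatter), which exchanges one halogen for another and bears little on swapping a halogen for a phenyl ring. Compound 1, which also carries a phenyl on the shared core, gives 0.046 nM, while compound 3 gives 0.015 nM; these two differ in more than one place, so their values give only a hint that a phenyl may go with a somewhat higher number. For compound 4 a step of a 2.0-fold higher number from compound 3 to compound 4 (0.30 log units; within the scatter) is therefore expected. The estimate for compound 4 in this assay is 0.03 nM, with a range from 0.008 nM to 0.12 nM.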

Compound 4, inhibition constant: 0.022 nM
For compound 4 the middle estimate is 1.4-fold (0.13 log units) above the measured one; the measured number falls inside the stated range.
By their numbers in this assay, from the lowest: compounds 3, 4, 2 and 1 (each within the scatter of the next, the first and the last beyond it).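

At this position, on an aromatic carbon ortho to a chloro group, a group of six heavy atoms can replace a single halogen atom with little effect in this assay. Phenyl in place of bromo gives a 1.5-fold higher number from compound 3 to compound 4 (0.17 log units; within the scatter), and phenyl in place of chloro gives a 1.0-fold lower number from compound 2 to compound 4 (0.02 log units; within the scatter), so neither exchange moves the number beyond the scatter. With the phenyl already present, chloro in place of hydrogen on an aromatic carbon gives a 2.1-fold lower number from compound 1 to compound 4 (0.32 log units; beyond the scatter), a modest step and the only one of the three beyond the scatter.

As far as these compounds go, whether an amine, a carboxylic acid or a longer chain at this position would keep the number in the same range remains open. No supporting measurement is available to explain any of these steps.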